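A few compounds are considered here, and "the series" means these few. Any claim that something is new, unique, unknown or untested is made for them only; others in the source may bear on it.

Measured compounds in a functional assay on PC-3 cells (Homo sapiens) for inhibition, read by MTT assay, with a stated time of 48 h; on this read-out higher numbers stand for weaker inhibition and lower numbers for stronger inhibition:
compound 1 `COc1cc(N(Cc2nc3ccccc3[nH]2)S(=O)(=O)c2ccc(C)cc2)cc(OC)c1OC`: 3340 nM
compound 2 `Cc1ccc(S(=O)(=O)N(Cc2nc3ccccc3[nH]2)c2ccc(Cl)cc2)cc1`: 42200 nM
compound 3 `Cc1ccc(N(Cc2nc3ccccc3[nH]2)S(=O)(=O)c2ccc(C)cc2)cc1`: 48900 nM

Compound 3 gives the highest of the three numbers in this assay; compound 2 sits nearest, compound 1 furthest, that gap lying beyond the scatter. Compound 4 `COc1ccc(N(Cc2nc3ccccc3[nH]2)S(=O)(=O)c2ccc(C)cc2)cc1OC` carries 3,4-dimethoxyphenyl in place of 4-methylphenyl on a sulfonamide nitrogen. Among the measured compounds shown here, no measured step changes this group on its own. The single step shown, a 1.2-fold higher number from compound 2 to compound 3 (0.06 log units; within the scatter), alters a different ring and stays within the scatter, so it says little here. Compound 1, whose ring on the sulfonamide nitrogen bears methoxy groups, shows a far lower number than compound 3, and compound 4 is therefore expected to move the same way, by an estimated 5.4-fold lower number from compound 3 to compound 4 (0.74 log units; beyond the scatter). Compound 4 is estimated at 9000 nM, range 3000 nM to 30000 nM.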

Compound 4, half-maximal inhibitory concentration: > 50000 nM
Compound 4 ended at the assay's limit; the forecaster's own chance of this, stated with the estimate: 5%; middle value at least 5.5-fold (0.74 log units) from the limit.
By their numbers in this assay, from the lowest: compound 1; then compounds 2 and 3 (each within the scatter of the next). At a limit, above all of these: compound 4.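

In this assay compound 4 gives > 50000 nM, which is a limit of the assay and not a number. Hydrogen in place of methoxy on an aromatic carbon gives an at least 14-fold higher number from compound 1 to compound 4 (1.17 log units; beyond the scatter), so on this ring the single methoxy lost from compound 1 counts heavily, and the two that remain do not hold the low number. The floors of an at least 1.0-fold higher number from compound 3 to compound 4 (0.00 log units; that floor lies within the scatter) and an at least 1.1-fold higher number from compound 2 to compound 4 (0.07 log units; that floor lies within the scatter) set no order among 3,4-dimethoxyphenyl, 4-methylphenyl and 4-chlorophenyl on the sulfonamide nitrogen.

Open, on these data alone, is the true value of compound 4. Also open, as far as these compounds go, is whether an amine or hydroxyl in place of that methoxy would keep the number of compound 1.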